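This account rests on a few compounds, and the source may have more. Where it says the series, first, only, none or still open, it means among the compounds named here.

In a functional assay on DU-145 cells (Homo sapiens) for inhibition, read by trypan blue exclusion, with a stated time of 96 h (on this read-out higher numbers stand for weaker inhibition of growth and lower numbers for stronger inhibition of growth), compound 3 `O=C(/C(=C\c1ccc(O)cc1O)Sc1ccccc1Br)c1ccc(Cl)cc1` gives 50000 nM. Compound 1 `Cc1ccc(S/C(=C/c2cc(Cl)cc(Cl)c2Cl)C(=O)c2ccc(Cl)cc2)cc1` gives 50000 nM, so these two stand level. Compound 2 `O=C(/C(=C\c1c(O)cc(O)cc1O)Sc1ccccc1Br)c1ccc(Cl)cc1` reads > 100000 nM, which is a limit of the assay and not a number.

Compound 4 `O=C(/C(=C\c1cc(Cl)cc(Cl)c1Cl)Sc1ccccc1Br)c1ccc(Cl)cc1` differs from compound 3 at one place: 2,3,5-trichlorophenyl in place of 2,4-dihydroxyphenyl on a double-bonded chain carbon bound to a double-bonded chain carbon. The swap of 2,4-dihydroxyphenyl for 2,3,5-trichlorophenyl sits on a double-bonded chain carbon bound to a double-bonded chain carbon.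

Within the data shown here, only one measured step touches the group that leaves: an at least 2.0-fold lower number from compound 2 to compound 3 (0.30 log units; that floor lies within the scatter), where hydrogen takes the place of hydroxy on that aromatic ring. This step is a floor rather than a true size, and that floor lies within the scatter, so it offers only weak guidance. A second clue comes from compound 1, which already carries 2,3,5-trichlorophenyl, with a different group on the sulfur, and gives 50000 nM. Together these point to no expected shift beyond the scatter in this assay, and a move in either direction remains possible.

The expected change is small, a 1.3-fold lower number from compound 3 to compound 4 (0.10 log units; within the scatter).

For compound 4 the estimated value is 40000 nM, with an expected range from 12000 nM to 100000 nM.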

Compound 4, concentration for 50% growth inhibition: 25000 nM
The estimate for compound 4 lay 1.6-fold (0.20 log units) above the measured number, within the range that was stated.
By their numbers in this assay, from the lowest: compounds 4, 1 and 3 (each within the scatter of the next). At a limit, above all of these: compound 2.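

In this assay, the step at this place gives a 2.0-fold lower number from compound 3 to compound 4 (0.30 log units; within the scatter) and so does not separate 2,3,5-trichlorophenyl from 2,4-dihydroxyphenyl: a ring with chlorine only and a ring with hydroxy groups read alike here. Among these compounds, the one step at this place that clears the scatter is an at least 4.0-fold lower number from compound 2 to compound 4 (0.60 log units; beyond the scatter), and its size is only a floor, since compound 2 stands at a limit and not at a number: the limit of > 100000 nM in this assay, at which 1 of the 4 values shown sits. With 2,3,5-trichlorophenyl held fixed, the change on the sulfur gives a 2.0-fold lower number from compound 1 to compound 4 (0.30 log units; within the scatter), so 2-bromophenyl and 4-methylphenyl also read alike there, and neither change at these two places gives a step beyond the scatter except the one that starts from the limit.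

What the compounds shown leave open is how far compound 2 truly lies from the others, and whether all three chlorines are needed or a single chlorine on this ring would read the same. On these data alone, it also stays open whether an amine or a carboxylic acid on this ring would give a number clearly different from those of compound 3 and compound 4.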